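Anilide acyl group enlarged from isopropyl to cyclohexyl

The source may report more compounds than this note shows. Statements on the series, on what has been measured and on what is new or still open speak of the compounds shown alone.

Measured compounds:
compound 1 `CC(=O)Nc1cccc(C2CCN(CCCC(=O)c3ccc(Cl)cc3)CC2)c1`: 70 nM
compound 2 `CC(C)C(=O)Nc1cccc(C2CCN(CCCC(=O)c3ccc(Cl)cc3)CC2)c1`: 5 nM

In an assay on isolated protein for displacement of a labelled ligand from melanin-concentrating hormone receptor 1 (Rattus norvegicus) (a lower number here means a stronger inhibitor, a higher number a weaker inhibitor), compound 2 holds the lowest of the two numbers; the next is compound 1, separated by a 14-fold lower number from compound 1 to compound 2 (1.15 log units; beyond the scatter). Compound 3 `O=C(CCCN1CCC(c2cccc(NC(=O)C3CCCCC3)c2)CC1)c1ccc(Cl)cc1` is not yet measured. It differs from compound 2 by cyclohexyl in place of isopropyl on a carbonyl carbon. Among the compounds with values here, the one step that bears on this place, a 14-fold lower number from compound 1 to compound 2 (1.15 log units; beyond the scatter), came with a larger acyl group and was large. A further enlargement is therefore expected to give at most a modest step downward, a 1.4-fold lower number from compound 2 to compound 3 (0.15 log units; within the scatter), possibly within the scatter. Compound 3 is estimated at 3.5 nM, with a range of 1 nM to 12 nM.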

Compound 3, inhibition constant: 200 nM
For compound 3 the middle estimate is 57-fold (1.76 log units) below the measured one, outside the stated range (above it).
By their numbers in this assay, from the lowest: compound 2; then compound 1; then compound 3.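

In this assay, enlarging the acyl group does not keep lowering the number: cyclohexyl in place of isopropyl on the carbonyl carbon gives a 40-fold higher number from compound 2 to compound 3 (1.60 log units; beyond the scatter) and so runs against a 14-fold lower number from compound 1 to compound 2 (1.15 log units; beyond the scatter) in direction. Across these three compounds the isopropyl amide sits at the low point, and the cyclohexyl amide also falls behind the methyl amide, with a 2.9-fold higher number from compound 1 to compound 3 (0.46 log units; beyond the scatter) as the step. No evidence at hand accounts for this reversal.

Open, on these data alone, is whether the loss follows the ring itself or the carbon count alone. Cyclopropyl, tert-butyl or an open hexyl chain at this carbonyl would separate the two.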